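A few compounds are considered here, and "the series" means these few. Any claim that something is new, unique, unknown or untested is made for them only; others in the source may bear on it.

Compound 2, `O=C(O)C1CC1c1ccc(NCc2cccc(Oc3ccccc3)c2)cc1`, gives 50.1 nM in a functional assay for agonist activity at Free fatty acid receptor 1 (Homo sapiens) (a higher number here means that more compound is needed for the effect, a lower number that less compound is needed), the lowest of the two numbers in hand; compound 1, `O=C(O)CCc1ccc(NCc2ccc(Cl)cc2)cc1`, gives 1000 nM, a higher number beyond the usual scatter. Compound 3, `O=C(O)CCCc1ccc(NCc2cccc(Oc3ccccc3)c2)cc1`, differs from compound 2 by 3-carboxypropyl in place of 2-carboxycyclopropyl on an aromatic carbon. Among the compounds with values here, with no measured pair showing this change, the expected step from compound 2 to compound 3 in this assay is a 3.2-fold higher number from compound 2 to compound 3 (0.50 log units; beyond the scatter), toward a higher number and modestly beyond the scatter. For compound 3 the estimate in this assay is 160 nM, within a range from 50 nM to 600 nM.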

Compound 3, half-maximal effective concentration: 3160 nM
Compound 3: the middle estimate sits 20-fold (1.30 log units) below what was measured; measured number outside the range, above it.
By their numbers in this assay, from the lowest: compound 2; then compound 1; then compound 3.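

At this position, on an aromatic carbon para to a large group, 3-carboxypropyl does not stand in for 2-carboxycyclopropyl in this assay: the change gives a 63-fold higher number from compound 2 to compound 3 (1.80 log units; beyond the scatter). The two groups match in heavy atoms, donors and acceptors, so the large step comes with a difference that these counts do not capture, the three-membered ring being present only in the group that leaves. Nothing at hand accounts for the size of this step. Still open, as far as these compounds go, is how 2-carboxycyclobutyl or carboxymethyl would read at this position on the same core.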